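Aryl swap on the triazole nitrogen: compound 3 to compound 4

A few compounds are considered here, and "the series" means these few. Any claim that something is new, unique, unknown or untested is made for them only; others in the source may bear on it.

Measured in a functional assay on NCI-H322 cells (Homo sapiens) for cytotoxicity, read by MTT assay, with a stated time of 24 h; on this read-out lower numbers stand for stronger inhibition and higher numbers for weaker inhibition:
compound 1 `COc1ccc(/C=C\C(=O)O)c(OCc2cn(-c3ccc(NC(C)=O)cc3)nn2)c1CC=C(C)C` gives 45700 nM
compound 2 `COc1ccc(/C=C\C(=O)O)c(OCc2cn(-c3ccc(NC(=O)c4ccccc4)cc3)nn2)c1CC=C(C)C` gives 17200 nM
compound 3 `COc1ccc(/C=C\C(=O)O)c(OCc2cn(-c3ccccc3F)nn2)c1CC=C(C)C` gives 45600 nM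

Among the measured compounds shown here, compound 3 sits second highest of the three numbers in this assay ; compound 1 is within the scatter of it, compound 2 is the only value beyond, as a 2.7-fold lower number from compound 1 to compound 2 (0.42 log units; beyond the scatter) shows. Compound 4 `COc1ccc(/C=C\C(=O)O)c(OCc2cn(-c3cccc(C#N)c3)nn2)c1CC=C(C)C` carries the change (3-cyanophenyl in place of 2-fluorophenyl on an aromatic nitrogen). For the measured compounds named here, the only measured step at that same position is a 1.0-fold lower number from compound 1 to compound 3 (0.00 log units; within the scatter), which stayed within the scatter; the other step, on the carbonyl carbon, does not bear on the triazole substituent. Compound 4 is therefore expected to lie close to compound 3, an estimated step of a 1.1-fold lower number from compound 3 to compound 4 (0.06 log units; within the scatter), with no direction beyond the scatter. The estimate for compound 4 is 40000 nM, range 15000 nM to 100000 nM.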

Compound 4, half-maximal inhibitory concentration: 26500 nM
Compound 4: middle estimate off by 1.5-fold (0.18 log units), on the high side; the range from low to high includes it.
By their numbers in this assay, from the lowest: compounds 2, 4, 3 and 1 (each within the scatter of the next, the first and the last beyond it).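

With 3-cyanophenyl on the aromatic nitrogen, the read-out gives a 1.7-fold lower number from compound 3 to compound 4 (0.24 log units; within the scatter) and a 1.7-fold lower number from compound 1 to compound 4 (0.24 log units; within the scatter), so a nitrile-bearing aryl group joins 2-fluorophenyl and 4-acetamidophenyl with no step beyond the scatter. Among these three aryl groups, the read-out does not separate one from another at this position. No measured evidence explains this outcome.

As far as these compounds go, whether an amine on the aryl group, or a longer alkyl chain in its place, would move the number beyond the scatter remains open.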